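Ring exchange on the amine nitrogen: notes towards compound 3

A few compounds are considered here, and "the series" means these few. Any claim that something is new, unique, unknown or untested is made for them only; others in the source may bear on it.

Compound 1 `CC1CCN(C(=O)[C@H](CCCNc2ccccn2)NS(=O)(=O)c2ccc3ccccc3c2)CC1` gives 6.9
Compound 2 `CC1CCN(C(=O)[C@H](CCCNc2cccnn2)NS(=O)(=O)c2ccc3ccccc3c2)CC1` gives 5.2

In a physicochemical assay for acid dissociation, compound 2 reads 5.2 and is the lower of the two measured numbers. Compound 3 `CC1CCN(C(=O)[C@H](CCCNc2ncccn2)NS(=O)(=O)c2ccc3ccccc3c2)CC1` brings pyrimidin-2-yl in place of pyridazin-3-yl on an amine nitrogen and has pyrimidin-2-yl in place of pyridazin-3-yl on an amine nitrogen. Among the compounds with values here, the one measured step bearing on this is a number 1.70 log units lower from compound 1 to compound 2 (beyond the scatter) and it was large, also a ring exchange on an amine nitrogen. On that basis a further fall beyond the scatter is expected, with a number 1.40 log units lower from compound 2 to compound 3 (beyond the scatter) as the estimated step in this assay. Compound 3 is estimated at 3.8 with an expected range from 3.2 to 4.5 in this reading.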

Compound 3, acid dissociation constant: 3.5
Compound 3: middle estimate off by 0.30 log units, on the high side; measured number inside the range.
By their numbers in this assay, from the lowest: compound 3; then compound 2; then compound 1.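

Pyridazin-3-yl and pyrimidin-2-yl have identical counts of heavy atoms, nitrogens and hydrogen-bond acceptors, yet exchanging one for the other on the amine nitrogen gives, in this assay, a number 1.70 log units lower from compound 2 to compound 3 (beyond the scatter) as the step. Taken across the series, the exchange of rings at this position gives a number 3.40 log units lower from compound 1 to compound 3 (beyond the scatter) as the overall step, so the reading here spans a wide range. Nothing measured here accounts for either step.

Still open, as far as these compounds go, is where a pyrazin-2-yl ring on the amine nitrogen would fall relative to these three rings. Also open, from the compounds shown here alone, is whether their order survives with a longer chain on that nitrogen.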